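Naphthalen-1-yl for 4-ethylphenyl: expected inhibition of compound 4

A few compounds are considered here, and "the series" means these few. Any claim that something is new, unique, unknown or untested is made for them only; others in the source may bear on it.

Three compounds have been measured in a functional assay on NCI-H522 cells (Homo sapiens) for inhibition, read by sulforhodamine B assay, with a stated time of 48 h, tested at 10 uM; a lower number here means less inhibition, a higher number more inhibition at the concentration tested (going by the name of the read-out):
compound 1, `CC(=O)c1ccc(-c2cn3ccnc3c(-c3ccc4ncn(C5CCCCC5)c4c3)n2)cc1`: 10.4%
compound 2, `Brc1ccc(-c2cn3ccnc3c(-c3ccc4ncn(C5CCCCC5)c4c3)n2)cc1`: 35.5%
compound 3, `CCc1ccc(-c2cn3ccnc3c(-c3ccc4ncn(Cc5ccccc5)c4c3)n2)cc1`: 45.9%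

Compound 3 gives the highest of the three numbers, with compound 2 the nearest below it and compound 1 the furthest, both gaps beyond the scatter. For the measured compounds named here, the one measured step, a number 25.1 percentage points higher from compound 1 to compound 2 (beyond the scatter), shows that altering the aryl group at this site shifts the read-out noticeably.

Compound 4, `c1ccc(Cn2cnc3ccc(-c4nc(-c5cccc6ccccc56)cn5ccnc45)cc32)cc1`, differs from compound 3 in one place: naphthalen-1-yl in place of 4-ethylphenyl on an aromatic carbon. The step from compound 1 to compound 2 exchanged a substituent on that aryl ring rather than the ring itself, so it gives no direction for this change. Compound 4 is therefore expected to stay close to compound 3, with a number 3.9 percentage points lower from compound 3 to compound 4 (within the scatter), an estimate of 42% within 22% to 62%.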

Compound 4, a percentage reported as inhibition, at one concentration (the size of the read-out at that concentration, not a potency): 29.3%
For compound 4 the middle estimate is 12.7 percentage points above the measured one, within the range that was stated.
By their numbers in this assay, from the lowest: compound 1; then compounds 4 and 2 (each within the scatter of the next); then compound 3.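

In this assay the exchange of the whole aryl ring at this site, naphthalen-1-yl in place of 4-ethylphenyl, gives a number 16.6 percentage points lower from compound 3 to compound 4 (beyond the scatter) and so shows that the read-out responds to the ring itself, not only to a substituent on it. Nothing measured here bears on why the number falls. The compounds shown leave open how an amine or a carboxylic acid on the phenyl ring, in place of ethyl, would read in this assay and whether naphthalen-1-yl would give a similar step on the core of compound 2.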